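The compounds below may be only part of what the source reports. "The series", "measured", "known", "first", "only" and "open" are said of these compounds alone.

Working notes on the series. Compound 1 `COc1cc(-c2cc(/C=C/C(=O)c3ccc(Cl)c(Cl)c3)[nH]n2)cc(OC)c1OC` has been examined in a functional assay on MDA-MB-435 cells (Homo sapiens) for inhibition, read by sulforhodamine B assay, with a stated time of 48 h; on this read-out lower numbers stand for stronger inhibition of growth and higher numbers for weaker inhibition of growth. In this assay compound 1 reaches only a limit of the assay, > 100000 nM, so no number is known for it. Its standing on the numbers shown is therefore described only by the limit of > 100000 nM in this assay, at which 1 of the 2 values shown sits; it sits at the limit and nowhere more precisely. Within the data shown here, compound 2 `COc1ccc(-c2cc(/C=C/C(=O)c3cc(OC)c(OC)c(OC)c3)[nH]n2)cc1OC` carries the same enone-linked core with different aryl groups, and in this assay compound 2 gives 4050 nM; no single-point step connects compound 2 to compound 1, so the two values are only placed side by side.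

Compound 3 `COc1cc(-c2cc(/C=C/C(=O)c3ccc(F)c(F)c3)[nH]n2)cc(OC)c1OC` remains to be measured in this assay. It differs from compound 1 by 3,4-difluorophenyl in place of 3,4-dichlorophenyl on a carbonyl carbon. The halogen swap leaves the rest of the molecule untouched, and compound 1 itself gives only a limit, so there is little to anchor a direction. The step from compound 1 to compound 3 is expected to be small or none beyond the scatter, an at least 1.2-fold lower number from compound 1 to compound 3 (0.09 log units; that floor lies within the scatter). Compound 3 is expected to give 80000 nM in this assay, within a range of 20000 nM to 200000 nM.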

Compound 3, concentration for total growth inhibition: 13300 nM
For compound 3 the middle estimate is 6.0-fold (0.78 log units) above the measured one; measured number outside the range, below it.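

In this assay, the position on a carbonyl carbon whose other neighbour is the double-bonded chain carbon responds to the identity of the halogen pair alone: 3,4-difluorophenyl in place of 3,4-dichlorophenyl gives an at least 7.5-fold lower number from compound 1 to compound 3 (0.87 log units; beyond the scatter). Among these compounds, the two groups match in heavy-atom count, ring and hydrogen-bond counts, so the swap of chlorine for fluorine is the only difference behind a step that lies beyond the scatter. Compound 1 gives > 100000 nM, which is a limit of the assay and not a number, and the step is a floor whose full size stays unknown because compound 1 has only that limit: the limit of > 100000 nM in this assay, at which 1 of the 3 values shown sits.

The compounds shown leave open how this position responds to other groups, such as plain phenyl, 3,4-dibromophenyl or a pyridine ring, and so whether the read-out follows the halogen in any regular way. Among the compounds shown here, they also leave open whether the same swap gives a step of similar size when the other aryl group on the shared core is changed, since only one pair differing in one place is available.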